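The source may hold more compounds than are shown below. What is called first, only, known or untested is meant among the compounds shown, and "the series" means these compounds.

- Compound 1 `Cc1cc(=O)c2c(O)cc(OCc3ccc([N+](=O)[O-])cc3)c([C@H]3CCN(C)C[C@H]3O)c2o1`: 14%
- Compound 2 `CCN(CC)Cc1c(O)c([C@H]2CCN(C)C[C@H]2O)c2oc(C)cc(=O)c2c1O`: 47%
- Compound 3 `Cc1cc(=O)c2c(O)c(CN3CCC(N4CCCCC4)CC3)c(O)c([C@H]3CCN(C)C[C@H]3O)c2o1`: 34%

In a functional assay on HL-60 cells (Homo sapiens) for inhibition, read by MTT assay, with a stated time of 48 h, tested at 10 uM (on this read-out lower numbers stand for less inhibition of growth and higher numbers for more inhibition of growth at the one concentration tested), compound 2 gives 47%, the highest of the three numbers, and compound 3 and compound 1 both lie lower, beyond the usual scatter. Compound 4 `Cc1cc(=O)c2c(O)c(CN(C)CC(=O)O)c(O)c([C@H]3CCN(C)C[C@H]3O)c2o1` has not yet been measured. It carries (carboxymethyl)(methyl)amino in place of diethylamino on a saturated chain carbon bound to an aromatic carbon. Among the measured compounds shown here, no measured pair shows this change alone, so the expectation in this assay is loose and rests only on the spread of the three values: a moderate fall in growth inhibition, beyond the scatter. The estimated change is a number 22 percentage points lower from compound 2 to compound 4 (beyond the scatter). For compound 4 the expected value is 25%, with an estimated range of 8% to 42%.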

Compound 4, percent growth inhibition at one concentration: 23%
Beside the measured number, compound 4's estimate is 2 percentage points above it; the measured number falls inside the stated range.
By their numbers in this assay, from the lowest: compounds 1 and 4 (each within the scatter of the next); then compound 3; then compound 2.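

In this assay, putting (carboxymethyl)(methyl)amino in place of diethylamino on a saturated chain carbon bound to an aromatic carbon gives a number 24 percentage points lower from compound 2 to compound 4 (beyond the scatter). With the rest of the molecule unchanged, this pair shows that growth inhibition at the one concentration tested responds to the group carried on this chain carbon. No supporting measurement accounts for the fall. The compounds shown leave open whether the fall follows the carboxylic acid itself or the loss of the ethyl groups; a methyl ester of that acid or a dimethylamino group on the same chain carbon would separate the two.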